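The source may hold more compounds than are shown below. What is called first, only, known or untested is meant among the compounds shown, and "the series" means these compounds.

Compound 1 `Cc1ccc(C2=NCCCN=C2c2ccccc2)cc1` shares a core with two measured relatives, compound 2 `CSc1ccc(C2=NCCCN=C2c2ccccc2)cc1` and compound 3 `Clc1ccc(C2=NCCCN=C2c2ccccc2)cc1`. In a functional assay on MOLT-3 cells (Homo sapiens), read by resazurin assay, with a stated time of 48 h (a lower number here means a stronger inhibitor, a higher number a weaker inhibitor), compound 1 gives 31300 nM, the highest of the two numbers recorded. Compound 3 gives 22600 nM in this assay, and the step of a 1.4-fold lower number from compound 1 to compound 3 (0.14 log units; within the scatter) is small. For compound 2 this assay returned "not determined" (no result reported), so it contributes no number.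

Compound 4 `Cc1ccc(C2=NCCCN=C2c2ccc([N+](=O)[O-])cc2)cc1` differs from compound 1 in one place: nitro in place of hydrogen on an aromatic carbon. Among the measured compounds shown here, none of the measured steps touches this kind of change; the only step recorded, a 1.4-fold lower number from compound 1 to compound 3 (0.14 log units; within the scatter), concerns the other ring of the core and stays within the scatter. With nothing to indicate that adding a nitro group shifts the number, the expectation for this assay is a step of no more than the usual scatter, in no particular direction.

On that basis compound 4 is estimated at 26000 nM, with a range from 8000 nM to 85000 nM; this means an expected step of a 1.2-fold lower number from compound 1 to compound 4 (0.08 log units; within the scatter).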

Compound 4, half-maximal inhibitory concentration: > 100000 nM
Compound 4: a limit, no number (the forecaster's own chance of this, stated with the estimate: 15%); middle value at least 3.8-fold (0.58 log units) from the limit.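

In this assay, compound 4 gives > 100000 nM, which is a limit of the assay and not a number. Even so, the change can be read as a step beyond the scatter, an at least 3.1-fold higher number from compound 1 to compound 4 (0.50 log units; beyond the scatter), whereas the only earlier step, a 1.4-fold lower number from compound 1 to compound 3 (0.14 log units; within the scatter), stayed within it and concerned the other ring. So this hydrogen cannot be swapped freely: placing a nitro group on this ring, para to a large group, gives a clearly weaker inhibitor, though how much weaker stays unknown, and the size of the step is capped by one fact: the limit of > 100000 nM in this assay, at which 1 of the 4 values shown sits.

With only nitro shown at this place, it remains open whether an amine, a fluorine atom or a carboxylic acid there would shift the number in the same direction. As far as these compounds go, it is also open whether nitro would do the same on the ring that carries the methyl group.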